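A Methoxy Step on the Amide Side Chain

A few compounds are considered here, and "the series" means these few. Any claim that something is new, unique, unknown or untested is made for them only; others in the source may bear on it.

The shared core of compound 1 `O=C(Nc1cc(Br)cc2c(=O)cc(C(=O)O)oc12)c1ccccc1` carries a benzamide, and in an assay on CHO cells for agonist activity at G protein-coupled receptor GPR35 (Rattus norvegicus), read by a beta-galactosidase reporter and beta-arrestin recruitment, with a stated time of 90 min (a lower number here means that less compound is needed, a higher number that more compound is needed for the effect), compound 1 gives 2750 nM. Compound 3 `Cc1cccc(C(=O)Nc2cccc3c(=O)cc(C(=O)O)oc23)c1` carries a different substitution on the core and a methyl on the benzamide ring; in this assay compound 3 gives 2750 nM, level with compound 1 at the digits shown, so no order between the two can be stated. Compound 2 `O=C1N/C(=N/c2ccccc2F)S/C1=C\c1ccc(C(=O)O)cc1` has a different scaffold and in this assay gives 8000 nM, the highest of the three numbers and beyond the scatter from compound 1.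

Compound 4 `COc1ccccc1C(=O)Nc1cc(Br)cc2c(=O)cc(C(=O)O)oc12` is reached from compound 1 by one change: methoxy in place of hydrogen on an aromatic carbon. Among the measured compounds shown here, no measured pair in the set reports the effect of this change, so the direction rests on nothing but the structural step itself. The measured compounds leave the benzamide ring tolerant of a small substituent, as compound 3 shows. For compound 4 the expected value is 2000 nM, within 700 nM to 6000 nM, and the expected step from compound 1 to compound 4 is a 1.4-fold lower number from compound 1 to compound 4 (0.14 log units; within the scatter), close to no change beyond the scatter.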

Compound 4, half-maximal effective concentration: 1100 nM
The estimate for compound 4 lay 1.8-fold (0.26 log units) above the measured number, and the stated range covers the measured number.
By their numbers in this assay, from the lowest: compound 4; then compounds 1 and 3 (each within the scatter of the next); then compound 2.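

In this assay, among the compounds shown here, going from phenyl to 2-methoxyphenyl gives a 2.5-fold lower number from compound 1 to compound 4 (0.40 log units; beyond the scatter), the first step in the set that isolates a single place on the molecule. This aromatic carbon, ortho to a large group, therefore accepts a methoxy group, and the number falls rather than rises. For the compounds shown here, none of the earlier compounds could show this. No two of them differed in one place alone. Nothing measured here accounts for this step.

The compounds shown leave open whether a hydroxyl, an ethoxy or a fluorine on this same carbon would shift the number in the same direction. They also leave open whether methoxy on another carbon of this ring would give a comparable step, and whether an amine there would be accepted at all.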